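A Second Fluoro on the Sulfonyl Aryl Ring

The source may hold more compounds than are shown below. What is called first, only, known or untested is meant among the compounds shown, and "the series" means these compounds.

compound 1 `O=C(NO)c1ccc(N(Cc2ccc(C(F)(F)F)cc2)C(=O)CN(Cc2ccccc2C(F)(F)F)S(=O)(=O)c2ccc(F)c(F)c2)cc1`: 396 nM
compound 2 `O=C(NO)c1ccc(N(Cc2ccc(C(F)(F)F)cc2)C(=O)CN(Cc2ccccc2C(F)(F)F)S(=O)(=O)c2ccc(F)cc2)cc1`: 304 nM
compound 3 `O=C(NO)c1ccc(N(Cc2ccc(C(F)(F)F)cc2)C(=O)CN(Cc2c(F)c(F)c(F)c(F)c2F)S(=O)(=O)c2ccc(F)cc2)cc1`: 191 nM

These three compounds share one core and were all measured in an assay on Sf9 cells for inhibition of histone deacetylase 11 (Homo sapiens), read by mobility shift assay; a lower number here means a stronger inhibitor, a higher number a weaker inhibitor. Compound 2 stands second highest of the three numbers, and both steps that touch it lie within the scatter: a 1.3-fold lower number from compound 1 to compound 2 (0.11 log units; within the scatter), and a 1.6-fold lower number from compound 2 to compound 3 (0.20 log units; within the scatter).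

Compound 4 `O=C(NO)c1ccc(N(Cc2ccc(C(F)(F)F)cc2)C(=O)CN(Cc2ccccc2C(F)(F)F)S(=O)(=O)c2ccc(F)cc2F)cc1` differs from compound 2 by fluoro in place of hydrogen on an aromatic carbon. Among the measured compounds shown here, the only measured step that adds or removes a fluoro on this same aryl ring is a 1.3-fold lower number from compound 1 to compound 2 (0.11 log units; within the scatter), and it stayed within the scatter. No step beyond the scatter is therefore expected for compound 4 in this assay. Compound 4 is expected to give about 300 nM, within a range of 150 nM to 600 nM. The expected step is a 1.0-fold lower number from compound 2 to compound 4 (0.01 log units; within the scatter).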

Compound 4, half-maximal inhibitory concentration: 346 nM
For compound 4 the middle estimate is 1.2-fold (0.06 log units) below the measured one; the measured number falls inside the stated range.
By their numbers in this assay, from the lowest: compounds 3, 2, 4 and 1 (each within the scatter of the next, the first and the last beyond it).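

In this assay, the new fluoro on the sulfonyl aryl ring gives only a 1.1-fold higher number from compound 2 to compound 4 (0.06 log units; within the scatter) and moving between the two difluoro patterns gives only a 1.1-fold lower number from compound 1 to compound 4 (0.06 log units; within the scatter), both within the scatter. Neither the second fluoro nor its place on this ring therefore separates these compounds in this assay. Nothing available explains this result. As far as these compounds go, whether chloro, methoxy or an amine at this place would give a step beyond the scatter stays open. So does the effect of pairing 2,4-difluorophenyl with the 2,3,4,5,6-pentafluorophenyl group.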